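A few compounds are considered here, and "the series" means these few. Any claim that something is new, unique, unknown or untested is made for them only; others in the source may bear on it.

Working notes on the series.

Compound 1 `CN(C)CCn1nc(Cc2ccc(Cl)cc2)c2ccccc2c1=O` is the reference. In an assay for binding affinity to Alpha-1A adrenergic receptor (Homo sapiens) (on this read-out higher numbers stand for weaker inhibition and lower numbers for stronger inhibition), compound 1 gives 158 nM, the lowest of the three numbers recorded. Compound 2 `COc1cccc(Cc2nn(C[C@H]3CCCN3C)c(=O)c3ccccc23)c1` gives 1580 nM in this assay, and compound 3 `CN(CCCCc1ccc(OCCCN2CCCCCC2)cc1)CCn1nc(Cc2ccc(Cl)cc2)c2ccccc2c1=O` gives 1580 nM; both stand higher than compound 1, and both gaps lie beyond the usual scatter. Compound 2 and compound 3 each differ from compound 1 in more than one place, so no single-change step between measured compounds is available, and nothing can be said about the cause of either gap.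

Compound 4 `CN1CCC(n2nc(Cc3ccc(Cl)cc3)c3ccccc3c2=O)CC1` has not been measured. It differs from compound 1 in one place: 1-methylpiperidin-4-yl in place of 2-(dimethylamino)ethyl on an aromatic nitrogen. Both groups carry one hydrogen-bond acceptor and no charge; the entering group brings a six-membered non-aromatic ring where the leaving group had none. With no measured step of this kind in the series, the step from compound 1 to compound 4 is expected to be small, a 1.6-fold higher number from compound 1 to compound 4 (0.20 log units; within the scatter), in either direction and possibly within the scatter. Compound 4 is therefore estimated at 250 nM in this assay, with a range from 60 nM to 1000 nM.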

Compound 4, inhibition constant: 15.9 nM
For compound 4 the middle estimate is 16-fold (1.20 log units) above the measured one; measured number outside the range, below it.
By their numbers in this assay, from the lowest: compound 4; then compound 1; then compounds 2 and 3 (each within the scatter of the next).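

In this assay, the group on the aromatic nitrogen proves sensitive to this change: a 9.9-fold lower number from compound 1 to compound 4 (1.00 log units; beyond the scatter), beyond the scatter, with 1-methylpiperidin-4-yl in place of 2-(dimethylamino)ethyl. This first single-change step in the series shows that the open chain is not required at this place, and that a six-membered non-aromatic ring there goes with the lower number. No measured property bears on this step, and no cause can be given.

The entering group differs from the leaving one in both its ring and its heavy-atom count, and the step does not tell these two apart. A piperidin-4-yl group without the methyl, or a longer chain such as 3-(dimethylamino)propyl, would bear on this, and the step is so far read only with the 4-chlorobenzyl group in place.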